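Trifluoromethyl in place of trifluoromethoxy: working notes

This account rests on a few compounds, and the source may have more. Where it says the series, first, only, none or still open, it means among the compounds named here.

In an ADME assay on L6 cells (Rattus norvegicus) for cytotoxicity, read by resazurin assay, with a stated time of 72 h (on this read-out higher numbers stand for weaker inhibition and lower numbers for stronger inhibition), compound 1 `O=[N+]([O-])c1cn2c(n1)OC(COc1cnc(-c3ccc(OC(F)(F)F)cc3)nc1)CC2` gives 70000 nM. Compound 2 `O=[N+]([O-])c1cn2c(n1)OC[C@@H](OCc1ccc(-c3ccc(OC(F)(F)F)cc3Cl)cc1)C2` gives 19000 nM, the lower of the two numbers, and its gap to compound 1 lies beyond the scatter. Compound 3 `O=[N+]([O-])c1cn2c(n1)OC[C@@H](OCc1ccc(-c3ccc(C(F)(F)F)cc3Cl)cc1)C2` keeps everything in compound 2 except one group: trifluoromethyl in place of trifluoromethoxy on an aromatic carbon, meta to a chloro group and para to a large group (trifluoromethyl in place of trifluoromethoxy on an aromatic carbon). Within the data shown here, no measured pair differs in one place, so no direct precedent for this change is available. In this assay no step beyond the scatter is expected, and no direction is favoured. The expected change is a 1.1-fold higher number from compound 2 to compound 3 (0.02 log units; within the scatter). Compound 3 is estimated at 20000 nM, with an expected range of 8000 nM to 50000 nM.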

Compound 3, half-maximal inhibitory concentration: 34000 nM
Compound 3: the middle estimate sits 1.7-fold (0.23 log units) below what was measured; the range from low to high includes it.
By their numbers in this assay, from the lowest: compounds 2 and 3 (each within the scatter of the next); then compound 1.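

In this assay, among these compounds, the step of a 1.8-fold higher number from compound 2 to compound 3 (0.25 log units; within the scatter) is the first comparison that differs in one place. It shows that, on the aromatic carbon meta to a chloro group and para to a large group, this read-out does not separate trifluoromethyl from trifluoromethoxy, so the oxygen of trifluoromethoxy can go without a step beyond the scatter. No measurement is available that bears on this result.

Still open, on these data alone, is how a group of another kind at this aromatic carbon, such as a nitrile, an amine or a carboxylic acid, would read in this assay. Also open, as far as these compounds go, is whether the same change would stay within the scatter in compound 1, which differs from compound 2 in more than one place.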